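The compounds below may be only part of what the source reports. "The series", "measured", "known", "first", "only" and "open" are said of these compounds alone.

Two compounds share one core and differ only in the group on the aromatic carbon para to it. Compound 1 `Cc1ccc(-n2nc3cc(C)oc(=O)c3c2C)cc1` gives 69.4% in a functional assay on the whole organism (strain Swiss albino) with Mus musculus as the target, with stated times of 30 min and 10 min, at a dose of 50 mg/kg by the oral route; on this read-out higher numbers stand for more inhibition at the one dose given (going by the name of the read-out) and lower numbers for less inhibition. Compound 2 `Cc1cc2nn(-c3ccc(Cl)cc3)c(C)c2c(=O)o1` gives 65.3% in this assay, and the step of a number 4.1 percentage points lower from compound 1 to compound 2 (within the scatter) shows that this assay does not separate the two; compound 2 stands beside compound 1, the pair within the usual scatter of each other. Compound 3 `Cc1cc2nn(-c3ccc(Br)cc3)c(C)c2c(=O)o1` is still to be measured. It differs from compound 2 by bromo in place of chloro on an aromatic carbon. For the measured compounds named here, the only step measured so far that bears on this place, a number 4.1 percentage points lower from compound 1 to compound 2 (within the scatter), stayed within the scatter, so a change from one halogen to the other at the same spot is expected to give no step beyond the scatter either: the estimated step is a number 0.3 percentage points lower from compound 2 to compound 3 (within the scatter). Compound 3 is therefore expected to give about 65% in this assay, within a range from 50% to 78%.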

Compound 3, a percentage reported as inhibition, in the whole organism at one dose (the size of the read-out at that dose, not a potency): 44.9%
For compound 3 the middle estimate is 20.1 percentage points above the measured one; measured number outside the range, below it.
By their numbers in this assay, from the lowest: compound 3; then compounds 2 and 1 (each within the scatter of the next).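

Read in this assay at the aromatic carbon para to a large group, bromo in place of chloro gives a number 20.4 percentage points lower from compound 2 to compound 3 (beyond the scatter) and bromo in place of methyl gives a number 24.5 percentage points lower from compound 1 to compound 3 (beyond the scatter) and thus shows that this position is not indifferent to the group it carries. The earlier pair had stayed within the scatter, yet the two halogens here are not interchangeable, and bromo stands apart from both chloro and methyl. The data offer nothing that explains this difference between bromo and the other two groups.

From the compounds shown here alone, whether the lower number belongs to bromo alone or extends to other groups on this carbon, such as fluoro, an amine or a carboxylic acid, remains open. Also open, going by these compounds, is whether bromo would give a similar step on a different core or at another dose.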